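The source may hold more compounds than are shown below. What is called first, only, known or untested is meant among the compounds shown, and "the series" means these compounds.

Within the data shown here, in an ADME assay on liver for metabolic stability, with Liver microsome (Rattus norvegicus) as the target, read by LC-MS, using microsomes, with a stated time of 5 h (on this read-out lower numbers stand for slow clearance and higher numbers for fast clearance), three compounds have numbers so far. Compound 1 `OC(c1ncccc1F)C1(c2ccc(Cl)c(Cl)c2)CCC1` gives 3000 mL/min/kg and compound 2 `OC(c1cc(F)ccn1)C1(c2ccc(Cl)c(Cl)c2)CCC1` gives 3850 mL/min/kg, so these two stand together within the scatter. Compound 3 `O[C@H](c1ccccn1)[C@]1(c2ccnc(C(F)(F)F)c2)C[C@H](O)C1`, which differs from them in several places, gives a far smaller 50 mL/min/kg.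

The next compound, compound 4 `OC(c1ccc(F)cn1)C1(c2ccc(Cl)c(Cl)c2)CCC1`, differs from compound 2 in one place: 5-fluoropyridin-2-yl in place of 4-fluoropyridin-2-yl on a saturated chain carbon bound to an oxygen on a saturated carbon and a saturated ring carbon. Here 5-fluoropyridin-2-yl takes the place of 4-fluoropyridin-2-yl on a saturated chain carbon bound to an oxygen on a saturated carbon and a saturated ring carbon. The two have the same atoms, joined differently.

Among the measured compounds shown here, only one measured step bears on this change: a 1.3-fold higher number from compound 1 to compound 2 (0.11 log units; within the scatter), where 4-fluoropyridin-2-yl replaced 3-fluoropyridin-2-yl. That step stayed within the scatter, although a single step is thin evidence. A similar swap is therefore expected to give no step beyond the scatter, in either direction. The expected step is a 1.2-fold lower number from compound 2 to compound 4 (0.07 log units; within the scatter). Compound 4 is estimated at 3300 mL/min/kg, with an expected range of 1700 mL/min/kg to 6000 mL/min/kg.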

Compound 4, clearance: 3170 mL/min/kg
For compound 4 the middle estimate is 1.0-fold (0.02 log units) above the measured one; the range from low to high includes it.
By their numbers in this assay, from the lowest: compound 3; then compounds 1, 4 and 2 (each within the scatter of the next).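

In this assay, 5-fluoropyridin-2-yl now joins 3-fluoropyridin-2-yl and 4-fluoropyridin-2-yl on the same saturated chain carbon, giving a 1.2-fold lower number from compound 2 to compound 4 (0.08 log units; within the scatter) and a 1.1-fold higher number from compound 1 to compound 4 (0.02 log units; within the scatter). Among these compounds, both steps lie within the scatter, so this read-out cannot tell the three fluoropyridinyl groups apart on this shared core, a wider result than the single earlier step could give. Nothing available explains why these swaps leave the number within the scatter.

These compounds all carry a fluorine, so they leave open whether an amine or a methoxy group in its place would shift the clearance. Compound 3 differs from them in several places, so its far smaller number cannot be tied to any single change.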